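A valinyl amide on the side chain of compound 1

The source may report more compounds than this note shows. Statements on the series, on what has been measured and on what is new or still open speak of the compounds shown alone.

Among the measured compounds shown here, compound 1 `CC1=C(C(C)C(=O)N(C)CCN(C)C)c2cc(F)ccc2/C1=C\c1ccc([S+](C)[O-])cc1` gives 44600 nM in a functional assay on PC-3 cells (Homo sapiens) for inhibition, read by CellTiter-Glo, with a stated time of 72 h (a lower number here means that less compound is tolerated, a higher number that more compound is tolerated), the highest of the two numbers measured so far. Its partner compound 2 `CC1=C(C(C)C(=O)N(CCNC(C)C)C(C)C)c2cc(F)ccc2/C1=C\c1ccc([S+](C)[O-])cc1` gives 15200 nM, and the change a 2.9-fold lower number from compound 1 to compound 2 (0.47 log units; beyond the scatter) concerns the amide nitrogen rather than the distal amine. Compound 3 `CC1=C(C(C)C(=O)N(C)CCN(C)C(=O)[C@@H](N)C(C)C)c2cc(F)ccc2/C1=C\c1ccc([S+](C)[O-])cc1` instead carries (1-amino-2-methylpropyl)carbonyl in place of methyl on an amine nitrogen. For the measured compounds named here, no measured step touches this position, so the single step offers only weak guidance, and a step within or close to the scatter is expected, a 1.5-fold lower number from compound 1 to compound 3 (0.17 log units; within the scatter). For compound 3 the estimate in this assay is 30000 nM, with a range from 10000 nM to 90000 nM.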

Compound 3, half-maximal cytotoxic concentration: 28800 nM
Estimate against measurement, compound 3: 1.0-fold (0.02 log units) above; the measured number falls inside the stated range.
By their numbers in this assay, from the lowest: compounds 2, 3 and 1 (each within the scatter of the next, the first and the last beyond it).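

Putting (1-amino-2-methylpropyl)carbonyl in place of methyl on the amine nitrogen, the first change shown at this position, gives in this assay a 1.5-fold lower number from compound 1 to compound 3 (0.19 log units; within the scatter). The position therefore takes this larger group of 7 heavy atoms, with its defined stereocentre, without a step beyond the scatter. No supporting measurement bears on this result.

The compounds shown leave open whether the opposite stereocentre of this group would give a similar number. They also leave open how a simple acetyl, or an acyl group ending in a carboxylic acid, would read at this nitrogen.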